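The source may hold more compounds than are shown below. What is called first, only, known or untested is meant among the compounds shown, and "the series" means these compounds.

Compound 1, `COc1cc(-c2cccc3nc(-c4ccc(F)cc4)oc23)cc(OC)c1OC`, is the starting point of this small series. In a functional assay on MCF7 cells (Homo sapiens) for antiproliferative activity, read by MTT assay, with a stated time of 48 h (a lower number here means a stronger inhibitor, a higher number a weaker inhibitor), compound 1 reaches only the limit of the assay, > 25000 nM. Compound 2, `COc1cc(-c2cccc3nc(-c4cccc(Cl)c4)oc23)cc(OC)c1OC`, carries 3-chlorophenyl in place of 4-fluorophenyl on an aromatic carbon. In this assay compound 2 likewise stops at the limit, > 25000 nM. The step that the two limits leave unreadable from compound 1 to compound 2 therefore has no readable size. Both measured values sit at one and the same limit, (the limit of > 25000 nM in this assay, at which 2 of the 2 values shown sit), so compound 2 stands at that limit with no numbered value beside it to set it against.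

Compound 3 is `COc1cc(-c2cccc3nc(-c4cccs4)oc23)cc(OC)c1OC`. It differs from compound 2 by thiophen-2-yl in place of 3-chlorophenyl on an aromatic carbon. Among the compounds with values here, only the single measured step bears on this change, and that step from compound 1 to compound 2 is of unreadable size; no sized step in this assay can be drawn from it. Since compound 2 sits at the limit > 25000 nM, compound 3 is expected to remain there as well, the expected step that the limit leaves unreadable from compound 2 to compound 3 being none beyond the scatter. Compound 3 is estimated at 30000 nM, within 8000 nM to 120000 nM.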

Compound 3, half-maximal inhibitory concentration: > 25000 nM
Compound 3: only a limit was reported; the forecaster's own chance of this, stated with the estimate: 80%; the middle value lies beyond the limit too.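

No step among compound 1, compound 2 and compound 3 can be read in this assay, since all three values are limits and not numbers: the limit of > 25000 nM in this assay, at which 3 of the 3 values shown sit.

The compounds shown leave open how the three compare with one another, and whether any group at this place on the shared core would give a numbered value in this assay.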